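The source may report more compounds than this note shows. Statements on the series, on what has been measured and on what is new or still open speak of the compounds shown alone.

In an ADME assay on PANC-1 cells (Homo sapiens) for cytotoxicity, read by sulforhodamine B assay, with a stated time of 48 h, tested at 10 uM (on this read-out lower numbers stand for less inhibition and higher numbers for more inhibition at the one concentration tested (going by the name of the read-out)), compound 1 `CCCCc1cn(C(c2ccccc2)c2cc3cc(Br)ccc3nc2OC)nn1` gives 5.46%. Compound 2 `COc1nc2ccc(Br)cc2cc1C(c1ccccc1)n1cc(-c2ccccc2F)nn1` gives 14.7% and compound 3 `CCOC(=O)c1cn(C(c2ccccc2)c2cc3cc(Br)ccc3nc2OC)nn1` gives 15.4%, so compound 2 stands second highest of the three numbers, with a number 9.2 percentage points higher from compound 1 to compound 2 (within the scatter) and a number 0.7 percentage points higher from compound 2 to compound 3 (within the scatter) both within the scatter, as is a number 9.9 percentage points higher from compound 1 to compound 3 (within the scatter). Compound 4 `COc1nc2ccc(Br)cc2cc1C(c1ccccc1)n1cc(-c2ccccc2C(F)(F)F)nn1` differs from compound 2 by trifluoromethyl in place of fluoro on an aromatic carbon. For the measured compounds named here, no measured step replaces fluoro with trifluoromethyl; the steps that exchange the group on the aromatic carbon of the shared core, a number 9.2 percentage points higher from compound 1 to compound 2 (within the scatter) and a number 0.7 percentage points higher from compound 2 to compound 3 (within the scatter), stay within the scatter, so for compound 4 no step beyond the scatter is expected in this assay. The estimate for compound 4 is 15%, between 3% and 30%, which corresponds to an expected step of a number 0.3 percentage points higher from compound 2 to compound 4 (within the scatter).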

Compound 4, a percentage reported as inhibition, at one concentration (the size of the read-out at that concentration, not a potency): 11.4%
The estimate for compound 4 lay 3.6 percentage points above the measured number, within the range that was stated.
By their numbers in this assay, from the lowest: compounds 1, 4, 2 and 3 (each within the scatter of the next).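

Trifluoromethyl in place of fluoro, on an aromatic carbon ortho to a large group, gives a number 3.3 percentage points lower from compound 2 to compound 4 (within the scatter) in this assay, so this change on the phenyl ring, from 1 heavy atom to 4, stays within the scatter. The other two steps, a number 4 percentage points lower from compound 3 to compound 4 (within the scatter) and a number 5.9 percentage points higher from compound 1 to compound 4 (within the scatter), also stay within the scatter, leaving all four compounds unseparated in this assay. No available evidence bears on a cause for these results.

From the compounds shown here alone, whether an amine or a carboxylic acid on the phenyl ring, or a longer chain in place of butyl, would give a step beyond the scatter remains open. Going by these compounds, the response at other concentrations also remains open.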